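Swapping one side chain on compound 1

The source may report more compounds than this note shows. Statements on the series, on what has been measured and on what is new or still open speak of the compounds shown alone.

Within the data shown here, compound 1 (`COc1ccc(N(C)c2nc(C)nc3ccccc23)cc1C(=O)OCCC[Se]C#N`) is one of only two compounds with a result so far. In a functional assay on RKO cells (Homo sapiens) for inhibition, read by MTT assay, with a stated time of 48 h (a higher number here means a weaker inhibitor, a lower number a stronger inhibitor), compound 1 gives 1140 nM and compound 2 (`Cc1nc(N(C)c2ccc(OCC[Se]C#N)cc2)c2ccccc2n1`) gives 652 nM as its result. These two numbers lie within the usual scatter of repeated measurements, so neither compound can be ranked ahead of the other.

The next compound, compound 3 (`COc1ccc(N(C)c2nc(C)nc3ccccc23)cc1OCCCC[Se]C#N`), keeps the core of compound 1 and differs in one place. The change is a group of 8 heavy atoms (5 carbon, 1 nitrogen, 1 oxygen, 1 selenium; no ring) in place of a group of 9 heavy atoms (5 carbon, 1 nitrogen, 2 oxygen, 1 selenium; no ring), on an aromatic carbon on an aromatic carbon of a six-membered aromatic ring of carbon only, ortho to a methoxy group.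

Among the measured compounds shown here, no measured pair of compounds differs in just one place, so the data give no direct size for this kind of step. For the measured compounds named here, the only guide is that compound 1 at 1140 nM and compound 2 at 652 nM lie close together, so a result near those two is expected. The estimated change is a 1.3-fold lower number from compound 1 to compound 3 (0.13 log units; within the scatter) and is expected to stay within the scatter. In this assay the expected result for compound 3 is 850 nM with an estimated range of 300 nM to 2400 nM as a working guess.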

Compound 3, half-maximal inhibitory concentration: 1360 nM
Compound 3: the middle estimate sits 1.6-fold (0.20 log units) below what was measured; the measured number falls inside the stated range.
By their numbers in this assay, from the lowest: compounds 2, 1 and 3 (each within the scatter of the next, the first and the last beyond it).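

Among these compounds, this is the first pair of compounds that differ in one place, so it gives the first direct size for a change at this position, on an aromatic carbon ortho to a methoxy group. In this assay, replacing the group of 9 heavy atoms, which has 2 oxygen atoms, 1 double bond and 3 hydrogen-bond acceptors, with the group of 8 heavy atoms, which has 1 oxygen atom, no double bond and 2 hydrogen-bond acceptors, gives a 1.2-fold higher number from compound 1 to compound 3 (0.08 log units; within the scatter), so the two numbers cannot be told apart. The data shown offer no measurement that accounts for this result.

The compounds shown leave open how a group of a different kind at this position would read in this assay, such as an amine, a carboxylic acid or a much longer chain. They also leave open what the selenium and nitrile end of the chain contributes, since each compound here carries it and none has a plain alkyl chain in its place.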